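This account rests on a few compounds, and the source may have more. Where it says the series, first, only, none or still open, it means among the compounds named here.

Three compounds share a common core and differ in the group carried at the far end of the chain. In a functional assay on A2780 cells (Homo sapiens) for inhibition, read by MTT assay, with a stated time of 72 h (on this read-out higher numbers stand for weaker inhibition of growth and lower numbers for stronger inhibition of growth), compound 1 `CC(C)(C)c1ccc(CNCCNS(=O)(=O)c2cc(C(F)(F)F)cc(C(F)(F)F)c2)cc1` gives 14000 nM. Compound 3 `O=S(=O)(NCCNCc1cccc2ccccc12)c1cc(C(F)(F)F)cc(C(F)(F)F)c1` gives 21000 nM in this assay, and the step of a 1.5-fold higher number from compound 1 to compound 3 (0.18 log units; within the scatter) shows that exchanging one aryl group for another hardly moves the number. Compound 2 `O=S(=O)(NCCCNCc1ccc(C(F)(F)F)cc1)c1cc(C(F)(F)F)cc(C(F)(F)F)c1` gives 2800 nM in this assay, the lowest of the three numbers, with gaps to compound 1 and compound 3 that both lie beyond the scatter. Compound 4 `O=S(=O)(NCCCNCc1ccccc1)c1cc(C(F)(F)F)cc(C(F)(F)F)c1` has not yet been measured in this assay; it differs from compound 2 by hydrogen in place of trifluoromethyl on an aromatic carbon. Within the data shown here, no step between measured compounds removes a trifluoromethyl group from this ring, so the only guide is the step from compound 1 to compound 3, which lies within the scatter and suggests that changes at this end of the molecule are tolerated. The expected step is therefore small, a 1.8-fold higher number from compound 2 to compound 4 (0.25 log units; within the scatter), leaning toward a somewhat higher number because compound 2 stands at 2800 nM and the other measured compounds sit well above it. Compound 4 is expected to give about 5000 nM in this assay, within a range from 1500 nM to 17000 nM.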

Compound 4, concentration for 50% growth inhibition: 4900 nM
For compound 4 the middle estimate is 1.0-fold (0.01 log units) above the measured one, and the stated range covers the measured number.
By their numbers in this assay, from the lowest: compounds 2 and 4 (each within the scatter of the next); then compounds 1 and 3 (each within the scatter of the next).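

In this assay, among these compounds, hydrogen in place of trifluoromethyl on the aromatic carbon gives a 1.8-fold higher number from compound 2 to compound 4 (0.24 log units; within the scatter), and this is the first direct reading of this position, since no earlier pair differed only here. The one earlier step exchanged a whole aryl group, whereas this one removes a single group of 4 heavy atoms and leaves the rest of the molecule untouched, so the trifluoromethyl group is shown to be dispensable for this read-out in this pair: on this chain, 4-(trifluoromethyl)benzyl and benzyl cannot be told apart. This holds for this one pair only, and no measurement is available that could explain why the number stays within the scatter.

The compounds shown leave open whether other groups on this same aromatic carbon, such as a fluorine atom, a methoxy group, a nitrile or a carboxylic acid, would also leave the number within the scatter. They also leave open whether the exchange of trifluoromethyl for hydrogen would read the same on a longer chain.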